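A few compounds are considered here, and "the series" means these few. Any claim that something is new, unique, unknown or untested is made for them only; others in the source may bear on it.

Measured in a functional assay on MCF7 cells (Homo sapiens) for cytotoxicity, read by colorimetric assay and MTT assay; on this read-out lower numbers stand for stronger inhibition and higher numbers for weaker inhibition:
Compound 1 `COc1cc(OC)c2cc(-c3ccccc3)c(O)nc2c1`: 10000 nM
Compound 2 `COc1cc(OC)c2cc(-c3ccc(OCc4ccccc4)cc3)c(O)nc2c1`: 10000 nM

For the measured compounds named here, with only two measured compounds, the picture is small. In this assay compound 2 gives 10000 nM, level with compound 1 at the digits shown.

The next structure to test is compound 3 `COc1cc(OC)c2cc(-c3ccc(O)cc3)c(O)nc2c1`. It differs from compound 2 in one place: hydrogen in place of benzyl on an oxygen on an aromatic ring. In words, this is hydrogen in place of benzyl on an oxygen on an aromatic ring, so benzyloxy becomes hydroxy.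

Going by the values given here, only one measured step bears on this change: no change at the digits printed from compound 1 to compound 2 (within the scatter), in which benzyloxy took the place of hydrogen on an aromatic carbon. That step was within the scatter, so the benzyloxy group made no visible difference here. Among the compounds with values here, no measured compound yet carries the hydroxy group, which leaves the evidence thin and the range wide.

The expectation is therefore for no step beyond the scatter and no particular direction, and the estimated step is no change at the digits printed from compound 2 to compound 3 (within the scatter). For compound 3 the expected value is 10000 nM, with an estimated range from 4000 nM to 20000 nM.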

Compound 3, half-maximal inhibitory concentration: 10000 nM
The estimate for compound 3 equals the measured number at the digits printed; the measured number falls inside the stated range.
By their numbers in this assay, from the lowest: compounds 1, 2 and 3 (each within the scatter of the next).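

The change from benzyloxy to hydroxy, with hydrogen in place of benzyl on an oxygen on an aromatic ring, gives no change at the digits printed from compound 2 to compound 3 (within the scatter) in this assay. Placing hydroxy on the aromatic carbon that bears hydrogen in the simplest compound gives no change at the digits printed from compound 1 to compound 3 (within the scatter), so this position has now been read with hydrogen, benzyloxy and hydroxy, and all three changes stay within the scatter of this cell test. Nothing measured here explains why these changes leave the number in place.

For the compounds shown here, an amine, a carboxylic acid, a fluorine atom or a longer chain on the oxygen could still give a different result at this position, as the three compounds cover only three groups there. The compounds also leave open whether a change elsewhere on the shared core, such as replacing one of its methoxy groups, would move the value in this assay, since every change so far has been made at this one place.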